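This account rests on a few compounds, and the source may have more. Where it says the series, first, only, none or still open, it means among the compounds named here.

In a functional assay (aorta) with Rattus norvegicus as the target (on this read-out lower numbers stand for an effect already at smaller amounts and higher numbers for an effect only at larger amounts of compound), compound 1 `COc1ccc(-c2nc(/N=C(\N)N3CCOCC3)sc2-c2ccc(OC)cc2)cc1` gives 66 uM, compound 2 `COc1ccc(-c2nc(CN)sc2-c2ccc(OC)cc2)cc1` gives 7.7 uM and compound 3 `COc1ccc(-c2nc(CNC(=O)CSC)sc2-c2ccc(OC)cc2)cc1` gives 6 uM. Compound 3 therefore shares the low end of these numbers with compound 2. The data show a 1.3-fold lower number from compound 2 to compound 3 (0.11 log units; within the scatter), within the scatter, and an 11-fold lower number from compound 1 to compound 3 (1.04 log units; beyond the scatter), beyond it. Compound 4 `COc1ccc(-c2nc(CNC(=O)N3CCOCC3)sc2-c2ccc(OC)cc2)cc1` brings one change to compound 3: morpholin-4-yl in place of (methylsulfanyl)methyl on a carbonyl carbon. The closest evidence is the small step already named, where a group on this amine nitrogen left the number within the scatter. Compound 1 also holds a morpholine-type ring, but an 8.6-fold lower number from compound 1 to compound 2 (0.93 log units; beyond the scatter) changes a much larger piece, so it gives only a mild warning of an upward move. In this assay the expected step is a 1.5-fold higher number from compound 3 to compound 4 (0.18 log units; within the scatter), which would stay within the scatter. The estimated value for compound 4 is 9 uM, with an expected range from 3 uM to 30 uM.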

Compound 4, concentration for half-maximal effect: 12 uM
Compound 4: middle estimate off by 1.3-fold (0.12 log units), on the low side, and the stated range covers the measured number.
By their numbers in this assay, from the lowest: compounds 3, 2 and 4 (each within the scatter of the next); then compound 1.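

In this assay, the data show a 2.0-fold higher number from compound 3 to compound 4 (0.30 log units; within the scatter) and a 1.6-fold higher number from compound 2 to compound 4 (0.19 log units; within the scatter), so a ring on this carbonyl carbon, morpholin-4-yl with its six heavy atoms, fits the same range as the open (methylsulfanyl)methyl chain and the free amine. With a 5.5-fold lower number from compound 1 to compound 4 (0.74 log units; beyond the scatter), a six-membered non-aromatic ring with two hetero atoms is present on both sides of a step beyond the scatter, so such a ring alone does not go with the high number of compound 1. No measurement on hand explains these results. On these data alone, what remains open is whether a carboxylic acid or a longer chain on this carbonyl carbon would stay in the same range.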